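This account rests on a few compounds, and the source may have more. Where it says the series, first, only, none or still open, it means among the compounds named here.

Compound 1 `Fc1ccc(-n2c(S)nnc2Sc2nnc(-c3ccccc3)n2-c2ccccc2)cc1` is one of the measured compounds, and in a functional assay on HT-29 cells (Homo sapiens) for inhibition, read by MTT assay, with a stated time of 48 h (on this read-out higher numbers stand for weaker inhibition and lower numbers for stronger inhibition), compound 1 gives 32800 nM.
Compound 3 `Sc1nnc(Sc2nnc(-c3ccccc3)n2-c2ccccc2)n1-c1ccc(Cl)cc1` is the other measured compound, and in this assay compound 3 gives 38400 nM.
Compound 2 `CC(C)n1c(S)nnc1CSc1nnc(-c2ccccc2)n1-c1ccccc1` has no result in this assay, where compound 2 stands as "not determined" (no result reported).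

Compound 2 therefore has no number of its own, and where it stands cannot be said. Compound 4 `Sc1nnc(CSc2nnc(-c3ccccc3)n2-c2ccccc2)n1-c1ccccc1` differs from compound 2 by phenyl in place of isopropyl on an aromatic nitrogen. Among the compounds with values here, the only measured step, a 1.2-fold higher number from compound 1 to compound 3 (0.07 log units; within the scatter), concerns a different group at a different place and does not bear on this change, so no direction or size of step in this assay can be read from it. The only anchors are the weak inhibition shown by compound 1 and compound 3, which share the shared core with an aromatic ring on that nitrogen. Compound 4 is expected to lie near 35000 nM, with a range from 10000 nM to 120000 nM.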

Compound 4, half-maximal inhibitory concentration: 5490 nM
The estimate for compound 4 lay 6.4-fold (0.80 log units) above the measured number, and the stated range ends above it.
By their numbers in this assay, from the lowest: compound 4; then compounds 1 and 3 (each within the scatter of the next).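

Within the data shown here, compound 2 has no number, so no step from it to compound 4 can be read. The compounds shown leave open how phenyl and isopropyl on that aromatic nitrogen compare in this assay. Nothing available explains the value of compound 4.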